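Swapping the sulfonyl aryl group: from compound 2 to compound 4

The source may report more compounds than this note shows. Statements on the series, on what has been measured and on what is new or still open speak of the compounds shown alone.

Of the compounds shown here, three share a core and have been measured in an ADME assay on microsomes from liver (Homo sapiens) for metabolic stability, tested at 2.5 uM; a higher number here means faster removal of the compound, a lower number slower removal. Compound 1 `COc1ccc(-c2c(S(=O)(=O)c3cc(Cl)cc(Cl)c3)cnc3cc(F)ccc23)cc1` gives 1 mL/min, compound 3 `O=S(=O)(c1cc(Cl)cc(Cl)c1)c1cnc2cc(F)ccc2c1-c1ccccc1F` gives 0.93 mL/min, and compound 2 `COc1cccc(S(=O)(=O)c2cnc3cc(F)ccc3c2-c2cccc(F)c2)c1` gives 3.36 mL/min. Compound 2 therefore stands highest of the three, beyond the scatter from both others.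

Compound 4 `O=S(=O)(c1ccc(F)cc1)c1cnc2cc(F)ccc2c1-c1cccc(F)c1` is not yet measured. It differs from compound 2 as follows: 4-fluorophenyl in place of 3-methoxyphenyl on a sulfonyl sulfur.

For the measured compounds named here, only one measured step exists, a 1.1-fold lower number from compound 1 to compound 3 (0.03 log units; within the scatter), and it concerns the group on the aromatic carbon, not the group on the sulfonyl sulfur, so it does not bear directly on the present change. Going by the values given here, what the values do show is that compound 2, the only one carrying 3-methoxyphenyl on the sulfonyl sulfur, is also the one with the highest number, while compounds 1 and 3, with a different group there, sit together at the low end. On that thin basis a lower number is expected for compound 4, with a step of about a 1.9-fold lower number from compound 2 to compound 4 (0.27 log units; within the scatter), though it may not reach beyond the scatter. The estimate for compound 4 in this assay is 1.8 mL/min, with a range from 0.7 mL/min to 4.5 mL/min.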

Compound 4, intrinsic clearance in a liver preparation (reported as CLH), per the amount of preparation that the assay uses: 0.95 mL/min
Beside the measured number, compound 4's estimate is 1.9-fold (0.28 log units) above it; the measured number falls inside the stated range.
By their numbers in this assay, from the lowest: compounds 3, 4 and 1 (each within the scatter of the next); then compound 2.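

In this assay, putting 4-fluorophenyl in place of 3-methoxyphenyl on the sulfonyl sulfur gives a 3.5-fold lower number from compound 2 to compound 4 (0.55 log units; beyond the scatter), with the rest of the molecule unchanged. Compound 2 differs from compound 1 and from compound 3 in more than one place, so those comparisons could not tie its higher number to any single group, whereas this pair isolates the group on the sulfonyl sulfur and shows that changing it alone can move the number beyond the scatter. Nothing available here explains why the number falls with this swap.

This single swap alters both the substituent, methoxy to fluoro, and its numbered place on the phenyl ring, so the compounds shown cannot say which of the two matters; 3-fluorophenyl and 4-methoxyphenyl on the sulfonyl sulfur would pull them apart. Also open, going by these compounds, are whether the step keeps its size with a different group on the aromatic carbon, and how the number responds to an unsubstituted phenyl or an amine such as piperidine on the sulfonyl sulfur.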